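Methyl to Ethyl on a Ring Amine Nitrogen

The source may report more compounds than this note shows. Statements on the series, on what has been measured and on what is new or still open speak of the compounds shown alone.

Compound 1 `CC(C)N1CC[C@H](NC(=O)c2cc(-c3ccc(NS(=O)(=O)c4cccc(Cl)c4Cl)cc3)nc3[nH]ncc23)C1` gives 38 nM in an assay for inhibition of serine/threonine-protein kinase Sgk1 (Homo sapiens), with stated times of 30 min and 60 min, in the presence of a further agent that is not named here; a higher number here means a weaker inhibitor, a lower number a stronger inhibitor.
Compound 2 `O=C(NC1CCN(CC2CC2)C1)c1cc(-c2ccc(NS(=O)(=O)c3cccc(Cl)c3Cl)cc2)nc2[nH]ncc12` gives 35 nM in this assay.
Compound 3 `CN1CCC(CNC(=O)c2cc(-c3ccc(NS(=O)(=O)c4cccc(Cl)c4Cl)cc3)nc3[nH]ncc23)C1` gives 45 nM in this assay.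

Compound 3 carries the highest of the three numbers, yet a 1.2-fold higher number from compound 1 to compound 3 (0.07 log units; within the scatter) and a 1.3-fold higher number from compound 2 to compound 3 (0.11 log units; within the scatter) both stay within the scatter, as does a 1.1-fold lower number from compound 1 to compound 2 (0.04 log units; within the scatter). All three measured steps exchange the group on the amide-type nitrogen, and none of them moves the number beyond the scatter. Compound 4 `CCN1CCC(CNC(=O)c2cc(-c3ccc(NS(=O)(=O)c4cccc(Cl)c4Cl)cc3)nc3[nH]ncc23)C1` differs from compound 3 by methyl in place of hydrogen on a saturated chain carbon bound to an amine nitrogen in a ring. For the measured compounds named here, no measured step matches this exact change, but the three exchanges already seen in that region left the numbers essentially unchanged, so no step beyond the scatter is expected in this assay, as no change at the digits printed from compound 3 to compound 4 (within the scatter) expresses. Compound 4 is therefore estimated at 45 nM, in a range from 22 nM to 90 nM.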

Compound 4, half-maximal inhibitory concentration: 109 nM
Compound 4: the middle estimate sits 2.4-fold (0.38 log units) below what was measured; measured number above the stated range.
By their numbers in this assay, from the lowest: compounds 2, 1 and 3 (each within the scatter of the next); then compound 4.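

In this assay, swapping methyl for ethyl on the ring amine nitrogen brings a 2.4-fold higher number from compound 3 to compound 4 (0.38 log units; beyond the scatter) and so, unlike the earlier exchanges, moves beyond the scatter. The other two pairs show the same separation, with a 3.1-fold higher number from compound 2 to compound 4 (0.49 log units; beyond the scatter) and a 2.9-fold higher number from compound 1 to compound 4 (0.46 log units; beyond the scatter) on top of that, so a single added carbon here counts for more than the earlier exchanges of the whole group did. Going by these compounds, what a propyl chain or a plain hydrogen on that nitrogen would do to the number stays open. Nothing available here explains this step.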